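A few compounds are considered here, and "the series" means these few. Any claim that something is new, unique, unknown or untested is made for them only; others in the source may bear on it.

Of the compounds shown here, three sharing one core have been tested in an ADME assay on the whole organism with Oryza sativa as the target, tested at 0.1 uM; a lower number here means a stronger effect, a higher number a weaker effect of the compound at the concentration tested. Compound 1 `C[C@@H](NC(=O)Nc1cccc(F)c1)c1ccccc1` gives 99%, compound 2 `C[C@@H](NC(=O)Nc1ccc(F)cc1)c1ccccc1` gives 98%, and compound 3 `C[C@@H](NC(=O)Nc1cccc(F)c1F)c1ccccc1` gives 100%; all three lie within the scatter of one another. Compound 3 arises from compound 1 by fluoro in place of hydrogen on an aromatic carbon, a change that gave a number 1 percentage points higher from compound 1 to compound 3 (within the scatter). The difference between the cores of compound 1 and compound 2 is not broken down here. Compound 4 `C[C@@H](NC(=O)Nc1ccc(F)cc1F)c1ccccc1` awaits measurement; it arises from compound 2 by fluoro in place of hydrogen on an aromatic carbon, the same kind of change as that from compound 1 to compound 3, though there the entering fluoro is ortho to a fluoro group, whereas here it is meta to a fluoro group. That earlier step, a number 1 percentage points higher from compound 1 to compound 3 (within the scatter), stayed within the scatter, so a step of similar size is expected here, a number 1 percentage points higher from compound 2 to compound 4 (within the scatter). Compound 4 is therefore estimated at 99%, between 94% and 100%.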

Compound 4, a percentage reported as activity, at one concentration (the size of the read-out at that concentration, not a potency): 100%
Compound 4: middle estimate off by 1 percentage points, on the low side, and the stated range covers the measured number.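

In this assay, fluoro in place of hydrogen on an aromatic carbon gave a number 2 percentage points higher from compound 2 to compound 4 (within the scatter), and this step agrees with the earlier one on the other core: the same change on two cores in this assay, a number 1 percentage points higher (within the scatter) from compound 1 to compound 3 and a number 2 percentage points higher (within the scatter) from compound 2 to compound 4, 1 percentage points apart, within the scatter of two such steps Across these two pairs, then, the change carried from one core to the other with no difference beyond the scatter. Because both steps lie within the scatter, this does not show that the change has any effect of its own in either core, and two pairs do not establish how it would behave on further cores.

The compounds shown leave open whether a different group on the aromatic ring, such as a methoxy, an amine or a carboxylic acid, would give a step beyond the scatter. They also leave open what a longer chain in place of the methyl would do.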